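Benzylamine variation on a bis(trifluoromethyl)benzenesulfonamide series

The source may report more compounds than this note shows. Statements on the series, on what has been measured and on what is new or still open speak of the compounds shown alone.

Three compounds sharing a bis(trifluoromethyl)benzenesulfonamide core have been measured. Compound 1 `O=S(=O)(NCCCCNCc1ccc(Br)cc1)c1cc(C(F)(F)F)cc(C(F)(F)F)c1` gives 1700 nM in a functional assay on BXPC-3 cells (Homo sapiens) for inhibition, read by MTT assay, with a stated time of 72 h; a higher number here means a weaker inhibitor of growth, a lower number a stronger inhibitor of growth. Compound 2 `O=S(=O)(NCCCNCc1ccc(Cl)cc1)c1cc(C(F)(F)F)cc(C(F)(F)F)c1` gives 1600 nM, and compound 3 `O=S(=O)(NCCNCc1ccc(-c2ccccc2)cc1)c1cc(C(F)(F)F)cc(C(F)(F)F)c1` gives 1600 nM. Compound 1 sits at the upper edge of the three numbers, but this position carries no weight: the step of a 1.1-fold lower number from compound 1 to compound 2 (0.03 log units; within the scatter) lies within the scatter, and the values of compound 1 and compound 3 differ by no more than that either. Across the chain lengths and aryl substituents covered so far, the series is flat.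

Compound 4 `COc1cccc(CNCCCNS(=O)(=O)c2cc(C(F)(F)F)cc(C(F)(F)F)c2)c1` is the next member. Relative to compound 1 it carries (3-methoxybenzyl)amino in place of ((4-bromobenzyl)amino)methyl on a saturated chain carbon, three bonds along the chain from a sulfonamide nitrogen. Going by the values given here, the one measured step that bears on this change, a 1.1-fold lower number from compound 1 to compound 2 (0.03 log units; within the scatter), pairs a shortening of the chain with a change of halogen and produces nothing beyond the scatter; compound 3, with a different chain length and a biphenyl in place of the halogenated ring, likewise lands within the scatter of compound 1. There is therefore no basis for expecting a step beyond the scatter in this assay, in either direction.

For compound 4 the expected value is 1700 nM, with a range of 800 nM to 3600 nM, which corresponds to an expected step of no change at the digits printed from compound 1 to compound 4 (within the scatter).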

Compound 4, concentration for 50% growth inhibition: 1700 nM
Beside the measured number, compound 4's estimate shows no gap at the digits printed; the range from low to high includes it.
By their numbers in this assay, from the lowest: compounds 2, 3, 1 and 4 (each within the scatter of the next).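

In this assay, the step of no change at the digits printed from compound 1 to compound 4 (within the scatter) shows that (3-methoxybenzyl)amino in place of ((4-bromobenzyl)amino)methyl on a saturated chain carbon, three bonds along the chain from a sulfonamide nitrogen, leaves the number within the scatter, even though the change exchanges bromine for oxygen and adds a hydrogen-bond acceptor. Going by these compounds alone, the step of a 1.1-fold higher number from compound 2 to compound 4 (0.03 log units; within the scatter) is the first to keep the chain fixed and alter only the aryl group, and 3-methoxyphenyl in place of 4-chlorophenyl on a saturated chain carbon bound to an amine nitrogen also stays within the scatter, so the flatness no longer rests only on steps that change chain and ring together. No supporting evidence bears on why the numbers hold level.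

From the compounds shown here alone, whether a nitrile or a carboxylic acid on the aryl ring, or an amide in place of the amine, would give a step beyond the scatter remains open. The same holds for a longer chain, and for any effect of chain length alone with the aryl group held fixed.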